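The compounds below may be only part of what the source reports. "The series", "measured", "known", "first", "only" and "open" are said of these compounds alone.

Compound 1, whose structure is `NCCCCCCOc1ccc2c(=O)c(-c3ccc(O)cc3)coc2c1`, carries a terminal amino group on the chain that hangs from the shared core. In an assay (Cricetulus griseus) for inhibition of aldehyde dehydrogenase, mitochondrial (Homo sapiens) (a lower number here means a stronger inhibitor, a higher number a weaker inhibitor), compound 1 gives 100 nM. Two other compounds of the same family have been measured in this assay. Compound 2, with the structure `O=C(O)CCCCCOc1ccc2c(=O)cc(-c3ccc(O)cc3)oc2c1`, gives 3500 nM, and compound 3, with the structure `CCCCCCC(Oc1ccc2c(=O)c(-c3ccc(O)cc3)coc2c1)C(=O)O`, gives 2000 nM. Compound 1 therefore stands at the lowest number of the three measured compounds, and its distance to both compound 3 and compound 2 lies beyond the usual scatter of this assay, so it is the strongest inhibitor among them.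

Compound 4, whose structure is `O=c1c(-c2ccc(O)cc2)coc2cc(OCCCCCCO)ccc12`, has not yet been measured in this assay. It differs from compound 1 in a single place: hydroxy in place of amino on a saturated chain carbon, six bonds along the chain from an oxygen on an aromatic ring. Among the measured compounds shown here, no pair of measured compounds shows this exact change, so no measured step can be quoted for it. The two weaker measured compounds both carry an acidic group in place of the amine, which gives no direct guide to a neutral hydroxy group either. He expects a step from compound 1 to compound 4 of a 5.0-fold higher number from compound 1 to compound 4 (0.70 log units; beyond the scatter), toward a weaker inhibitor and beyond the scatter. For compound 4 in this assay he estimates 500 nM, with a likely range from 150 nM to 2000 nM.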

Compound 4, half-maximal inhibitory concentration: 120 nM
Beside the measured number, compound 4's estimate is 4.2-fold (0.62 log units) above it, and the stated range ends above it.
By their numbers in this assay, from the lowest: compounds 1 and 4 (each within the scatter of the next); then compounds 3 and 2 (each within the scatter of the next).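

With hydroxy in place of amino on a saturated chain carbon, six bonds along the chain from an oxygen on an aromatic ring, this assay gives a step of a 1.2-fold higher number from compound 1 to compound 4 (0.08 log units; within the scatter). Among the compounds shown here, this is the only measured step between compounds that differ in one place, and it shows that at this chain end, on the core of compound 1, the amino and hydroxy groups cannot be told apart in this measurement, which compounds 2 and 3 could not show, as each differs from compound 1 in more than one place. Nothing measured here explains why these two groups read alike.

Whether the chain end needs either group remains open, as the compounds shown include none on this core whose six-carbon chain ends in a plain methyl group, a methoxy group or an amide. On these data alone, how far this likeness extends also remains open, as it rests on one pair of compounds and says nothing about a shorter or longer chain carrying the same amino or hydroxy end.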